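Naphthyridine-type amide series: truncation of the amine side chain

The source may hold more compounds than are shown below. What is called first, only, known or untested is meant among the compounds shown, and "the series" means these compounds.

Measured so far:
- compound 1 `N[C@H]1CC[C@H](Nc2c(C(=O)NCc3ccc(Cl)cc3)nc(Br)c3cccnc23)CC1`: 4000 nM
- compound 2 `CNCCCNc1c(C(=O)NCc2ccc(F)cc2)nc(Br)c2cccnc12`: 9000 nM

In a functional assay on HCT-116 cells (Homo sapiens) for cytotoxicity, read by MTT assay, with a stated time of 72 h (on this read-out higher numbers stand for weaker inhibition and lower numbers for stronger inhibition), compound 2 gives 9000 nM and stands highest of the two numbers recorded; its nearest neighbour is compound 1 with 4000 nM, a gap that lies beyond the scatter. Among the measured compounds shown here, the two compounds differ in more than one place, so no single step between them is available.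

Compound 3 `CNc1c(C(=O)NCc2ccc(F)cc2)nc(Br)c2cccnc12` is not yet measured. Relative to compound 2 the change is hydrogen in place of 2-(methylamino)ethyl on a saturated chain carbon bound to a nitrogen on an aromatic ring. For the measured compounds named here, no matched step of this kind exists, so the expectation rests only on the standing of compound 2 itself. The estimated step is a 2.2-fold higher number from compound 2 to compound 3 (0.35 log units; beyond the scatter), expected to run toward a higher number, that is weaker inhibition, but of uncertain size. Compound 3 is therefore estimated at 20000 nM, with a range from 5000 nM to 80000 nM.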

Compound 3, half-maximal inhibitory concentration: > 20000 nM
Compound 3: no number, only a limit; the forecaster's own chance of this, stated with the estimate: 20%; the middle value sits exactly at the limit.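

In this assay, among the compounds shown here, the change from (3-(methylamino)propyl)amino to methylamino gives the first single-place step, an at least 2.2-fold higher number from compound 2 to compound 3 (0.34 log units; beyond the scatter), so shortening this side chain to methylamino does not retain the activity of the longer chain. Compound 3 gives > 20000 nM, which is a limit of the assay and not a number. The step therefore fixes a direction and a minimum size only, with its full size unread: the limit of > 20000 nM in this assay, at which 1 of the 3 values shown sits.

The compounds shown leave open whether the amine nitrogen of the 3-(methylamino)propyl group or the length of the chain carries this difference. A plain propyl chain without the amine, or a longer chain ending in an amine, would begin to separate the two.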